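A few compounds are considered here, and "the series" means these few. Any claim that something is new, unique, unknown or untested is made for them only; others in the source may bear on it.

Of the compounds shown here, two sharing one core have numbers so far in a functional assay on A549 cells (Homo sapiens) for inhibition, read by CCK-8 assay, with a stated time of 48 h; on this read-out lower numbers stand for stronger inhibition and higher numbers for weaker inhibition. There, compound 1 `COc1cc(-c2ccnc3cc(-c4ccccc4)nn23)cc(OC)c1OC` gives 208 nM, while compound 2 `C=Cc1ccc(-c2cc3nccc(-c4cc(OC)c(OC)c(OC)c4)n3n2)cc1` gives 1030 nM, the higher of the two numbers and so the weaker inhibition. Compound 3 `COc1cc(-c2ccnc3cc(-c4ccc5ccn(C)c5c4)nn23)cc(OC)c1OC` keeps the core but changes one group: 1-methyl-1H-indol-6-yl in place of 4-vinylphenyl on an aromatic carbon. In short, 1-methyl-1H-indol-6-yl stands in place of 4-vinylphenyl on an aromatic carbon. Within the data shown here, only one measured step bears on this change, a modest one beyond the scatter: a 5.0-fold higher number from compound 1 to compound 2 (0.69 log units; beyond the scatter), which came with vinyl in place of hydrogen on an aromatic carbon. Compound 3 no longer carries that vinyl group, so a move of similar size in the opposite direction seems likely. Among the measured compounds shown here, no tested compound carries the indolyl group, however, so the uncertainty is wide. The expected change in this assay is an estimated 5.2-fold lower number from compound 2 to compound 3 (0.71 log units; beyond the scatter). The expected value for compound 3 is 200 nM, with a range of 30 nM to 1000 nM.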

Compound 3, half-maximal inhibitory concentration: 829 nM
For compound 3 the middle estimate is 4.1-fold (0.62 log units) below the measured one; the measured number falls inside the stated range.
By their numbers in this assay, from the lowest: compound 1; then compounds 3 and 2 (each within the scatter of the next).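

In this assay the change gives a 1.2-fold lower number from compound 2 to compound 3 (0.09 log units; within the scatter), so two quite different groups on this aromatic carbon, 4-vinylphenyl and 1-methyl-1H-indol-6-yl, cannot be told apart here. The new step measured against plain phenyl gives a 4.0-fold higher number from compound 1 to compound 3 (0.60 log units; beyond the scatter), which shows that the earlier loss seen with the vinyl group is not unique to that group: among these three compounds, both groups with more atoms than phenyl give a higher number than compound 1 does. No measurement at hand offers an explanation for this pattern.

The three compounds leave open how a small group such as an amine or a carboxylic acid on the phenyl ring would behave at this place. They also leave open whether any group here could give a lower number than compound 1 does.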